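This account rests on a few compounds, and the source may have more. Where it says the series, first, only, none or still open, it means among the compounds named here.

Of the compounds shown here, three sharing one core have been measured in a functional assay on CHO cells for agonist activity at G-protein coupled receptor 52 (Homo sapiens), read by AlphaScreen and cAMP accumulation, with a stated time of 30 min; on this read-out lower numbers stand for an effect already at smaller amounts and higher numbers for an effect only at larger amounts of compound. Compound 1 `O=C(NCCO)c1cnn(-c2cccc3cc(Cc4cccc(C(F)(F)F)c4)sc23)c1` gives 87 nM. Compound 2 `COCCNC(=O)c1cn(-c2cccc3cc(Cc4cccc(C(F)(F)F)c4)sc23)nc1C` gives 9.6 nM, the second highest of the three numbers. Compound 3 `Cc1nn(-c2cccc3cc(Cc4cccc(C(F)(F)F)c4)sc23)cc1C(=O)NCCO` gives 5.2 nM; the gap from compound 2 to compound 3 is a 1.8-fold lower number from compound 2 to compound 3 (0.27 log units; within the scatter), so these two cannot be told apart, whereas compound 1 sits clearly further away, as shown by a 17-fold lower number from compound 1 to compound 3 (1.22 log units; beyond the scatter), a step made by a methyl in place of a hydrogen on the five-membered ring.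

Compound 4 `COCCNC(=O)c1c(C)nn(-c2cccc3cc(Cc4cccc(C(F)(F)F)c4)sc23)c1C`, not yet measured, differs from compound 2 in one place: methyl in place of hydrogen on an aromatic carbon. Among the measured compounds shown here, the only measured step of this kind, a 17-fold lower number from compound 1 to compound 3 (1.22 log units; beyond the scatter), concerns a methyl at a different place on the same ring, and no measured pair shows a methyl at the place changed here. Going by these compounds, that step was large and lowering, but whether a second methyl behaves alike is untested. The number expected for compound 4 is therefore close to that of compound 2, a 1.3-fold higher number from compound 2 to compound 4 (0.10 log units; within the scatter), within the scatter. The estimate for compound 4 is 12 nM, with a range from 3 nM to 60 nM.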

Compound 4, half-maximal effective concentration in the G-protein coupled receptor 52 assay: 17 nM
For compound 4 the middle estimate is 1.4-fold (0.15 log units) below the measured one; the measured number falls inside the stated range.
By their numbers in the G-protein coupled receptor 52 assay, from the lowest: compounds 3, 2 and 4 (each within the scatter of the next, the first and the last beyond it); then compound 1.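

In the G-protein coupled receptor 52 assay, a methyl on this aromatic carbon, next to the ring nitrogen, leaves compound 4 within the scatter of compound 2: a 1.8-fold higher number from compound 2 to compound 4 (0.25 log units; within the scatter). The same kind of change therefore does not carry over from one place on the ring to another, as the earlier large step gave no sign of: the same change on two cores in the G-protein coupled receptor 52 assay, a 17-fold lower number (1.22 log units; beyond the scatter) from compound 1 to compound 3 and a 1.8-fold higher number (0.25 log units; within the scatter) from compound 2 to compound 4, 30-fold (1.47 log units) apart, beyond the scatter of two such steps. Among the compounds shown here, in a physicochemical assay for solubility, read by HPLC, at pH 6.8 (on this read-out lower numbers stand for lower solubility and higher numbers for higher solubility), the same methyl comes with a clear difference that the earlier compounds could not show: the measured solubility of compound 2, < 0.1 ug/mL, and of compound 4, 2.9 ug/mL, an at least 29-fold higher number (1.46 log units; beyond the scatter).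

In the physicochemical assay, compound 2 gives < 0.1 ug/mL, which is a limit of the assay and not a number. In the physicochemical assay, compound 4 gives 2.9 ug/mL. Going by these compounds, the true size of that difference stays open, as compound 2 stands at a limit of the assay and not at a number: the limit of < 0.1 ug/mL in the physicochemical assay, at which 1 of the 2 values shown sits. On these data alone, whether an amine or an ethyl group on this same carbon would give a similar result in both assays also remains open.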